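A few compounds are considered here, and "the series" means these few. Any claim that something is new, unique, unknown or untested is made for them only; others in the source may bear on it.

In a functional assay on UACC-62 cells (Homo sapiens) for inhibition, read by sulforhodamine B assay, with a stated time of 48 h (on this read-out higher numbers stand for weaker inhibition of growth and lower numbers for stronger inhibition of growth), compound 1 `CC1(/C=C/c2ccc(F)cc2)C=CC(=O)O1` gives 55300 nM. Among the compounds with values here, the only other compound measured so far, compound 2 `COc1ccc(/C=C/C2(C)C=CC(=O)O2)c(OC)c1OC`, gives 71500 nM. These two values lie within the usual scatter of each other, so compound 1 cannot be ranked against compound 2. Compound 3 `COc1ccc(/C=C/C2(C)C=CC(=O)O2)cc1` has yet to be measured in this assay. It differs from compound 1 in a single place: methoxy in place of fluoro on an aromatic carbon. In words, this is methoxy in place of fluoro on an aromatic carbon. Within the data shown here, no measured pair isolates this change, so the expectation is indirect. It rests on compound 2, which also bears methoxy groups and gives 71500 nM. No step beyond the scatter is expected in this assay, and the estimated step is a 1.1-fold higher number from compound 1 to compound 3 (0.05 log units; within the scatter). Compound 3 is expected at 62000 nM, with an estimated range from 35000 nM to 100000 nM.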

Compound 3, concentration for total growth inhibition: 147000 nM
The estimate for compound 3 lay 2.4-fold (0.37 log units) below the measured number; measured number above the stated range.
By their numbers in this assay, from the lowest: compounds 1 and 2 (each within the scatter of the next); then compound 3.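

In this assay, within the data shown here, the exchange of fluoro for methoxy on an aromatic carbon now has a direct reading, which the earlier compounds did not provide. The change gives a 2.7-fold higher number from compound 1 to compound 3 (0.42 log units; beyond the scatter) and so weaker inhibition of growth, which shows that this position on the six-membered aromatic ring of carbon only is not indifferent to the group it carries, although the step is modest. Nothing among the data shown accounts for this step.

The compounds shown leave open how an amine, a carboxylic acid or a hydroxyl group would read at this position, since only fluoro and methoxy are seen there. They also leave open whether the same exchange would give a similar step when the aromatic ring carries further groups.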